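Replacing the imidazole ring with phenyl: compound 4

The compounds below may be only part of what the source reports. "The series", "measured", "known", "first", "only" and "open" are said of these compounds alone.

Going by the values given here, in a functional assay on NCI-H460 cells (Homo sapiens) for cytotoxicity, read by MTT assay, with a stated time of 72 h (a higher number here means a weaker inhibitor, a lower number a stronger inhibitor), compound 2 `O=c1[nH]/c(=C\c2c[nH]cn2)c(=O)[nH]/c1=C\c1cccc(Oc2ccc(F)cc2)c1` gives 479 nM, at the high end of the numbers so far and within the scatter of compound 3 `O=C(c1ccc(F)cc1)c1cccc(/C=c2\[nH]c(=O)/c(=C/c3c[nH]cn3)[nH]c2=O)c1` at 278 nM. Compound 1 `O=c1[nH]/c(=C\c2nc[nH]c2C2CC2)c(=O)[nH]/c1=C\c1cccc(Oc2ccc(F)cc2)c1` stands apart at 15.2 nM. Compound 4 `O=c1[nH]/c(=C\c2cccc(Oc3ccc(F)cc3)c2)c(=O)[nH]/c1=C\c1ccccc1` carries phenyl in place of 1H-imidazol-4-yl on a double-bonded chain carbon bound to an aromatic carbon, with phenyl in place of 1H-imidazol-4-yl on a double-bonded chain carbon bound to an aromatic carbon. Among the compounds with values here, no measured step replaces this ring. The closest guide is a 32-fold higher number from compound 1 to compound 2 (1.50 log units; beyond the scatter), a large step from a change on the same imidazole ring, whereas a 1.7-fold lower number from compound 2 to compound 3 (0.24 log units; within the scatter) stays within the scatter. A move to a higher number in this assay is therefore expected, with an estimated step of a 3.1-fold higher number from compound 2 to compound 4 (0.50 log units; beyond the scatter). For compound 4 the estimated value is 1500 nM, with an expected range of 400 nM to 6000 nM.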

Compound 4, half-maximal inhibitory concentration: 389 nM
Compound 4: middle estimate off by 3.9-fold (0.59 log units), on the high side; the measured number lies below the stated range.
By their numbers in this assay, from the lowest: compound 1; then compounds 3, 4 and 2 (each within the scatter of the next).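

In this assay the 1H-imidazol-4-yl of compound 2 gives way to phenyl with a 1.2-fold lower number from compound 2 to compound 4 (0.09 log units; within the scatter) and so, for this pair, the ring nitrogens and the hydrogen-bond donor and acceptor counted on the imidazole are not needed to hold the value. The large separation stays with the cyclopropyl-bearing ring of compound 1 (a 26-fold higher number from compound 1 to compound 4 (1.41 log units; beyond the scatter)). Nothing available gives a reason for either result.

As far as these compounds go, whether a cyclopropyl group on the phenyl ring of compound 4 would bring the number towards that of compound 1 stays open. So does the effect of an amine or a carboxylic acid on that ring.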